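Fluoro to bromo: what two measurements suggest

This account rests on a few compounds, and the source may have more. Where it says the series, first, only, none or still open, it means among the compounds named here.

Compound 1 `O=C(NS(=O)(=O)c1ccccc1)c1ccccn1`: 14200 nM
Compound 2 `O=C(NS(=O)(=O)c1ccc(F)cc1)c1ccccn1`: 10900 nM
Compound 3 `O=C(NS(=O)(=O)c1ccc(Br)cc1)c1ccccn1`: not yet measured

In a functional assay on B16-F10 cells (Mus musculus) for antiproliferative activity, read by colorimetric assay and MTT assay, with a stated time of 48 h (on this read-out lower numbers stand for stronger inhibition and higher numbers for weaker inhibition), compound 2 gives 10900 nM. For the measured compounds named here, only two compounds have numbers so far, and those of compound 1 and compound 2 cannot be told apart within the usual scatter.

Compound 3 keeps the shared core and changes one group: bromo in place of fluoro on an aromatic carbon. In words, this is bromo in place of fluoro on an aromatic carbon, para to a large group.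

Going by the values given here, one measured step bears on this change: a 1.3-fold lower number from compound 1 to compound 2 (0.11 log units; within the scatter), which put fluoro in place of hydrogen on an aromatic carbon. Among the compounds with values here, that step is small, but a single step is thin evidence, and no bromo compound has been measured yet. The expectation is therefore no step beyond the scatter in this assay, and no firm direction. The expected step is a 1.2-fold lower number from compound 2 to compound 3 (0.08 log units; within the scatter). For compound 3 the estimated value is 9000 nM, with an expected range of 4500 nM to 18000 nM.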

Compound 3, half-maximal inhibitory concentration: 8500 nM
For compound 3 the middle estimate is 1.1-fold (0.02 log units) above the measured one, and the stated range covers the measured number.
By their numbers in this assay, from the lowest: compounds 3, 2 and 1 (each within the scatter of the next).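

In this assay the exchange of fluoro for bromo gives a 1.3-fold lower number from compound 2 to compound 3 (0.11 log units; within the scatter) and so stays inside what repeated measurements would scatter by. Compared directly with the hydrogen of compound 1, bromo gives a 1.7-fold lower number from compound 1 to compound 3 (0.22 log units; within the scatter) and is again not separable from it, so at this aromatic carbon, para to a large group, hydrogen, fluoro and bromo cannot be told apart in this read-out, a wider statement than the single fluoro step could support. No measurement at hand speaks to what lies behind this flat picture.

On these data alone, all three compounds carry only hydrogen or a halogen at this place, so it remains open whether a quite different group, such as an amine, a carboxylic acid or a methoxy group, would move the number beyond the scatter or leave it just as flat. Also open, as far as these compounds go, is whether changes at other places on the shared core would matter more than this one does.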